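The compounds below may be only part of what the source reports. "The series", "measured", "known", "first", "only" and "open" are said of these compounds alone.

Going by the values given here, in a functional assay on PC-3 cells (Homo sapiens) for antiproliferative activity, read by MTT assay, with a stated time of 72 h (on this read-out lower numbers stand for stronger inhibition and higher numbers for weaker inhibition), compound 2 (`CCCCCCCCCNC[C@@H]1OC[C@H](N)[C@H]1O`) gives 7650 nM and holds the higher of the two numbers so far, while compound 1 (`CCCCCCCCCCCNC[C@@H]1OC[C@H](N)[C@@H]1O`) gives 3330 nM and lies beyond the scatter below it. Compound 3 (`CCCCCCCCCCNC[C@@H]1OC[C@H](N)[C@H]1O`) departs from compound 2 by methyl in place of hydrogen on a saturated chain carbon, nine bonds along the chain from an amine nitrogen. Among the compounds with values here, no measured pair shows such a step, and compound 1 at 3330 nM is the only lower number to lean on. In this assay a small move to a lower number, probably within the scatter, is expected, an estimated 1.5-fold lower number from compound 2 to compound 3 (0.18 log units; within the scatter) in all. Compound 3 is expected at 5000 nM (range 2500 nM to 10000 nM) once measured.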

Compound 3, half-maximal inhibitory concentration: > 128000 nM
Compound 3: a limit, no number; the forecaster's own chance of this, stated with the estimate: 5%; at least 25-fold (1.40 log units) between middle value and limit.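

In this assay, methyl in place of hydrogen on a saturated chain carbon, nine bonds along the chain from an amine nitrogen, now has a first measured step, and one added carbon at this place is enough for a large change: an at least 16-fold higher number from compound 2 to compound 3 (1.22 log units; beyond the scatter). Compound 3 holds a limit of the assay and not a number, so the full size of the step stays unknown: the limit of > 128000 nM in this assay, at which 1 of the 3 values shown sits.

On these data alone, whether ethyl or a hydroxyl group at this same place would give a measurable number remains open. The compounds shown also leave open what lies behind the step.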